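The source may hold more compounds than are shown below. What is called first, only, known or untested is meant among the compounds shown, and "the series" means these compounds.

Compound 1, with the structure `O=C(Nc1ccccc1)Nc1ccc(Oc2ccc(-c3nccs3)cc2)cc1`, shares its core with a small set of ureas in which one end of the urea carries a phenyl ring. In a functional assay on MDA-MB-231 cells (Homo sapiens) for inhibition, read by MTT assay and WST assay, with a stated time of 72 h, tested at 10 uM (a higher number here means more inhibition of growth at the concentration tested, a lower number less inhibition of growth), the entry for compound 1 reads "not determined" (no result reported), so no number places it on this scale. Two close relatives were measured: compound 2 (`O=C(Nc1ccc(Oc2ccc(-c3nccs3)cc2)cc1)Nc1cccc(C(F)(F)F)c1`) gives 64.1% in this assay, and compound 3 (`O=C(Nc1ccc(Oc2ccc(-c3nccs3)cc2)cc1)Nc1ccc(F)c(C(F)(F)F)c1`) gives 71.8%. For the measured compounds named here, the only measured step, a number 7.7 percentage points higher from compound 2 to compound 3 (within the scatter), changes a ring substituent on the far end and says nothing about swapping the ring itself.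

Compound 4 has the structure `CC(=O)Oc1sccc1NC(=O)Nc1ccc(Oc2ccc(-c3nccs3)cc2)cc1`. Its difference from compound 1 is 2-acetoxythiophen-3-yl in place of phenyl on an amide-type nitrogen. No measured step touches this kind of exchange, and compound 1 itself has no number, so the expectation rests only on the general level shown by compound 2 and compound 3 in this assay. Compound 4 is therefore estimated to give about 55% in this assay, within a wide range from 25% to 80%.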

Compound 4, percent growth inhibition at one concentration: 11%
The estimate for compound 4 lay 44 percentage points above the measured number; measured number below the stated range.
By their numbers in this assay, from the lowest: compound 4; then compounds 2 and 3 (each within the scatter of the next).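

Exchanging a substituted phenyl ring for 2-acetoxythiophen-3-yl on the amide-type nitrogen gives a number 60.8 percentage points lower from compound 3 to compound 4 (beyond the scatter) and a number 53.1 percentage points lower from compound 2 to compound 4 (beyond the scatter) in this assay for the same kind of exchange. Both steps replace the whole ring, which the earlier step did not do, and they show that growth inhibition at this end of the urea can depend strongly on which group is attached. No measurement available here bears on why the number falls.

As far as these compounds go, compound 4 brings in a new ring and an acetoxy group in one change, so the share of each remains open; a plain thiophen-3-yl group or a phenyl ring carrying acetoxy would separate them. From the compounds shown here alone, with no number for compound 1, the effect of replacing its unsubstituted phenyl directly also remains open.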